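The source may hold more compounds than are shown below. What is called first, only, known or untested is meant among the compounds shown, and "the series" means these compounds.

Going by the values given here, compound 1 `N#Cc1ccc(C(Nc2ccc(C(=O)O)cc2)c2ccc3cccnc3c2O)cc1` is the only member of this small set for which a number exists: in an assay on isolated protein for inhibition of CAAX prenyl protease 2 (Homo sapiens), with stated times of 60 s and 60 min (on this read-out higher numbers stand for weaker inhibition and lower numbers for stronger inhibition), compound 1 gives 16000 nM. Compound 2 `N#Cc1ccc(NC(c2ccccc2)c2ccc3cccnc3c2O)cc1` carries no result, as compound 2 stands in this assay at "not determined" (no result reported), and compound 3 `CCOC(=O)c1ccc(NC(c2ccc(F)cc2)c2ccc3cccnc3c2O)cc1` likewise stands in this assay at "not determined" (no result reported). Among the compounds with values here, no step between measured compounds can therefore be drawn. Compound 4 `O=C(O)c1ccc(NC(c2cccnc2)c2ccc3cccnc3c2O)cc1` differs from compound 1 by one change, (pyridin-3-yl in place of 4-cyanophenyl on a saturated chain carbon bound to an aromatic carbon and a nitrogen on an aromatic ring), that is, pyridin-3-yl in place of 4-cyanophenyl on a saturated chain carbon bound to an aromatic carbon and a nitrogen on an aromatic ring. With nothing measured to lean on, the step in this assay is expected to be small and without a clear direction beyond the scatter, so the expected shift is a 1.3-fold higher number from compound 1 to compound 4 (0.10 log units; within the scatter). Compound 4 is accordingly estimated at 20000 nM, within a range from 6000 nM to 60000 nM.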

Compound 4, half-maximal inhibitory concentration: 14000 nM
Estimate against measurement, compound 4: 1.4-fold (0.15 log units) above, within the range that was stated.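

In this assay, going by these compounds alone, pyridin-3-yl in place of 4-cyanophenyl on a saturated chain carbon gives a 1.1-fold lower number from compound 1 to compound 4 (0.06 log units; within the scatter) and so provides the first readable step in this set. At this position, one six-membered aromatic ring can replace another, and the nitrile can go, without a change beyond the scatter. No evidence shown gives a reason for this result. Going by these compounds, whether a cyclohexyl group or an aliphatic amine on this carbon, or an amide in place of the carboxylic acid, would move the number beyond the scatter stays open.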